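A nitro group on compound 2

The compounds below may be only part of what the source reports. "The series", "measured", "known", "first", "only" and "open" are said of these compounds alone.

Measured in a functional assay on A2780 cells (Homo sapiens) for cytotoxicity, read by MTT assay, with a stated time of 48 h; on this read-out lower numbers stand for stronger inhibition and higher numbers for weaker inhibition:
Compound 1 `CCn1cc(-c2nc3ccccc3[nH]2)c(=O)c2cc(F)c(N3CCNC(C)C3)c(F)c21` gives 11600 nM
Compound 2 `CCn1cc(-c2nc3ccccc3o2)c(=O)c2cc(F)c(N3CCNC(C)C3)c(F)c21` gives 83500 nM

Compound 2 stands highest of the two numbers (83500 nM). Compound 3 `CCn1cc(-c2nc3ccc([N+](=O)[O-])cc3o2)c(=O)c2cc(F)c(N3CCNC(C)C3)c(F)c21` differs from it by nitro in place of hydrogen on an aromatic carbon and has nitro in place of hydrogen on an aromatic carbon. For the measured compounds named here, no measured step involves nitro. Going by the values given here, the only guide to size is a 7.2-fold higher number from compound 1 to compound 2 (0.86 log units; beyond the scatter), which exchanged a different group. A modest step towards a lower number is therefore expected in this assay (a 2.1-fold lower number from compound 2 to compound 3 (0.32 log units; beyond the scatter)). For compound 3 the estimated value is 40000 nM (expected range 12000 nM to 110000 nM).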

Compound 3, half-maximal inhibitory concentration: 200 nM
Compound 3: middle estimate off by 200-fold (2.30 log units), on the high side; measured number below the stated range.
By their numbers in this assay, from the lowest: compound 3; then compound 1; then compound 2.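

In this assay, nitro in place of hydrogen on the six-membered aromatic ring of carbon only gives a 420-fold lower number from compound 2 to compound 3 (2.62 log units; beyond the scatter), so this ring of the fused system is a highly sensitive place for substitution. The earlier exchange, a 7.2-fold higher number from compound 1 to compound 2 (0.86 log units; beyond the scatter), altered only the ring atoms of the fused group and gave a much smaller step. Nothing available explains the size of the nitro step.

The compounds shown leave open whether an amine or a methoxy group on the same carbon would lower the number as well. They also leave open whether nitro would have a similar effect on the 1H-benzimidazol-2-yl group of compound 1.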